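Replacing an Amino Group with a Tetrazole Ring

This account rests on a few compounds, and the source may have more. Where it says the series, first, only, none or still open, it means among the compounds named here.

Compound 1, `N#Cc1ccc2ccc(C(=O)c3ccc(F)c(O)c3)nc2c1`, gives 56% in an assay for inhibition of 17-beta-hydroxysteroid dehydrogenase type 2 (Homo sapiens), read by HPLC, with a stated time of 10 min, tested at 1 uM; on this read-out lower numbers stand for less inhibition and higher numbers for more inhibition at the one concentration tested (going by the name of the read-out).
Compound 2, `Cc1cc(-c2ccc3ccc(C(=O)c4ccc(F)c(O)c4)nc3c2)ccc1O`, gives 80% in this assay.
Compound 3, `Nc1ccc2ccc(C(=O)c3ccc(F)c(O)c3)nc2c1`, gives 83% in this assay.

Among these three, compound 3 stands highest, though its gap to compound 2 is within the scatter, so the two cannot be ranked against each other; only the gap to compound 1 is beyond the scatter. The two steps from the cyano compound, a number 24 percentage points higher from compound 1 to compound 2 (beyond the scatter) and a number 27 percentage points higher from compound 1 to compound 3 (beyond the scatter), show that swapping the cyano for either an amino or a 4-hydroxy-3-methylphenyl group lifts the read-out by a modest amount, while a number 3 percentage points higher from compound 2 to compound 3 (within the scatter) shows that the choice between those two replacements makes no measurable difference.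

Compound 4, `O=C(c1ccc(F)c(O)c1)c1ccc2ccc(-c3nnn[nH]3)cc2n1`, is not yet measured in this assay. It differs from compound 3 in one place: 1H-tetrazol-5-yl in place of amino on an aromatic carbon. For the measured compounds named here, no measured step bears directly on a tetrazole at this position. The cyano of compound 1 and the tetrazole both lack the amino group, so a step of the size of a number 27 percentage points higher from compound 1 to compound 3 (beyond the scatter) in the opposite direction sets a rough lower end, while a step within the scatter remains possible. The expected step is a number 18 percentage points lower from compound 3 to compound 4 (beyond the scatter), and compound 4 is estimated at 65%, between 40% and 85%.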

Compound 4, a percentage reported as inhibition, at one concentration (the size of the read-out at that concentration, not a potency): 52%
Estimate against measurement, compound 4: 13 percentage points above; the range from low to high includes it.
By their numbers in this assay, from the lowest: compounds 4 and 1 (each within the scatter of the next); then compounds 2 and 3 (each within the scatter of the next).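

This position does not accept every group alike: in this assay, 1H-tetrazol-5-yl in place of amino gives a number 31 percentage points lower from compound 3 to compound 4 (beyond the scatter), and in place of 4-hydroxy-3-methylphenyl it gives a number 28 percentage points lower from compound 2 to compound 4 (beyond the scatter). In place of cyano it gives a number 4 percentage points lower from compound 1 to compound 4 (within the scatter), so the four compounds now fall into two levels, with compounds 1 and 4 on one and compounds 2 and 3 on the other. A hydrogen-bond donor on the group is not enough by itself to reach the upper level, since 1H-tetrazol-5-yl carries one just as amino does, yet only compound 3 stands there of those two.

Nothing at hand gives a reason for the fall from amino to the tetrazole. From the compounds shown here alone, it remains open whether a carboxylic acid, an acetamide or a methylamine at this position would stand with compounds 2 and 3 or with compounds 1 and 4, and whether these levels at a single concentration would hold in a full measure of potency.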